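A few compounds are considered here, and "the series" means these few. Any claim that something is new, unique, unknown or untested is made for them only; others in the source may bear on it.

Compound 1 `COC(=O)c1ccc(C2SCC(=O)N2c2ccc(N3CCN(Cc4cccc(C)c4)CC3)cn2)c(OC)c1` stands only at a limit in a functional assay on Jurkat cells (Homo sapiens) for antiproliferative activity, read by MTT assay and trypan blue exclusion, with a stated time of 72 h; a lower number here means a stronger inhibitor, a higher number a weaker inhibitor: compound 1 gives > 100000 nM, which is a limit of the assay and not a number (the limit of > 100000 nM in this assay, at which 1 of the 2 values shown sits). Compound 2 `COC(=O)c1ccc(C2SCC(=O)N2c2ccc(N3CCN(Cc4cccc([N+](=O)[O-])c4)CC3)cn2)c(OC)c1` carries nitro in place of methyl on an aromatic carbon, and in this assay compound 2 gives 37400 nM. That change yields an at least 2.6-fold lower number from compound 1 to compound 2 (0.42 log units; beyond the scatter).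

Compound 3 `COC(=O)c1ccc(C2SCC(=O)N2c2ccc(N3CCN(S(=O)(=O)c4ccc([N+](=O)[O-])cc4)CC3)cn2)c(OC)c1` differs from compound 1 by (4-nitrophenyl)sulfonyl in place of 3-methylbenzyl on an amine nitrogen in a ring. For the measured compounds named here, the measured step of an at least 2.6-fold lower number from compound 1 to compound 2 (0.42 log units; beyond the scatter) is the only one bearing on it, as it also brings nitro in; the sulfonyl linkage has no measured counterpart. A modest gain of an at least 2.2-fold lower number from compound 1 to compound 3 (0.34 log units; beyond the scatter) is therefore expected. Compound 3 is estimated at 45000 nM, with a range from 12000 nM to 150000 nM.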

Compound 3, half-maximal inhibitory concentration: 54000 nM
Compound 3: the middle estimate sits 1.2-fold (0.08 log units) below what was measured; the range from low to high includes it.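

Replacing 3-nitrobenzyl with (4-nitrophenyl)sulfonyl on the amine nitrogen in a ring gives a 1.4-fold higher number from compound 2 to compound 3 (0.16 log units; within the scatter), so this assay does not tell the sulfonyl linkage from the benzyl linkage when nitro is present. Against 3-methylbenzyl, the same group gives an at least 1.8-fold lower number from compound 1 to compound 3 (0.26 log units; that floor lies within the scatter). Compound 1 stands at a limit, so this step is only a floor: the limit of > 100000 nM in this assay, at which 1 of the 3 values shown sits.

The compounds shown do not separate the part played by nitro from that of the sulfonyl linkage. From the compounds shown here alone, a plain phenylsulfonyl group, or an amine or carboxylic acid in place of nitro, remains open.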